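The compounds below may be only part of what the source reports. "The series", "measured", "known", "first", "only" and "open" are said of these compounds alone.

Of the compounds shown here, three built on one shared core have been tested in a functional assay on HL-60 cells (Homo sapiens) for cytotoxicity, read by MTT assay, with a stated time of 48 h; on this read-out lower numbers stand for stronger inhibition and higher numbers for weaker inhibition. Compound 1, `Fc1cccc(-c2nc(Nc3ccccc3)c3cc(F)ccc3n2)c1`, gives 48300 nM in this assay. Compound 2, `COc1ccccc1Nc1nc(-c2cccc(F)c2)nc2ccc(F)cc12`, reaches only a limit of this assay, > 50000 nM. Compound 3, `Fc1cccc(-c2nc(Nc3ccccc3Cl)c3cc(F)ccc3n2)c1`, also stops at a limit, > 50000 nM. Compound 3 therefore stands at the limit of > 50000 nM in this assay, at which 2 of the 3 values shown sit, so its own number is not known, only that it lies beyond the range the assay can read.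

The step of an at least 1.0-fold higher number from compound 1 to compound 2 (0.01 log units; that floor lies within the scatter) and the step of an at least 1.0-fold higher number from compound 1 to compound 3 (0.01 log units; that floor lies within the scatter) both alter the phenyl ring on the amine nitrogen, and each is only a floor that sits within the scatter. The step that the two limits leave unreadable from compound 2 to compound 3 gives no readable size.

Compound 4, `Fc1cccc(-c2nc(Nc3cccc(Br)c3)c3cc(F)ccc3n2)c1`, is not yet measured. It differs from compound 3 by 3-bromophenyl in place of 2-chlorophenyl on a nitrogen on an aromatic ring. Among the compounds with values here, no measured step covers this exact exchange, and the two steps that touch the same ring were floors within the scatter, so no step beyond the scatter is expected in this assay. The expected step from compound 3 to compound 4 is therefore a step that the limit leaves unreadable from compound 3 to compound 4. Compound 4 is estimated at 55000 nM, within a range of 30000 nM to 120000 nM, most likely again reported only as a limit.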

Compound 4, half-maximal inhibitory concentration: > 50000 nM
Compound 4 ended at the assay's limit; the forecaster's own chance of this, stated with the estimate: 70%; the middle value is on the limit's open side.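

In this assay compound 4 gives > 50000 nM, which is a limit of the assay and not a number. Bromo in place of hydrogen on the ring gives an at least 1.0-fold higher number from compound 1 to compound 4 (0.01 log units; that floor lies within the scatter), so 3-bromophenyl, like 2-chlorophenyl and 2-methoxyphenyl, shows no stronger inhibition than the plain phenyl of compound 1, and the steps joining compound 2, compound 3 and compound 4 cannot be read, with limits at both ends. None of the substituted rings brings a value into the readable range: the limit of > 50000 nM in this assay, at which 3 of the 4 values shown sit.

Still open, from the compounds shown here alone, is whether an amine or a carboxylic acid on this ring would give a number the assay can read. Also open, going by these compounds, is how far past the limit compound 2, compound 3 and compound 4 lie.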